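A few compounds are considered here, and "the series" means these few. Any claim that something is new, unique, unknown or untested is made for them only; others in the source may bear on it.

Compound 1 `C=C(CC[C@H]1[C@@H](C)CCCC1(C)C)C(O)Cc1c(O)cc(C)c(C=O)c1O` is the reference point of this account. Going by the values given here, in a functional assay on EC17 cells (Homo sapiens) for inhibition, with a stated time of 24 h (on this read-out higher numbers stand for weaker inhibition and lower numbers for stronger inhibition), compound 1 gives 1980 nM, the lowest of the two numbers measured so far. Its nearest neighbour is compound 2 `C=C(CC[C@H]1[C@@H](C)CCCC1(C)C)C(O)Cc1c(OC)cc(C)c(C=O)c1O`, which in this assay gives 4570 nM; the step of a 2.3-fold higher number from compound 1 to compound 2 (0.36 log units; beyond the scatter) arises from methyl in place of hydrogen on an oxygen on an aromatic ring. Compound 3 `C=C(CCC1CCCCC1)C(O)Cc1c(O)cc(C)c(C=O)c1O` differs from compound 1 elsewhere: cyclohexyl in place of 2,2,6-trimethylcyclohexyl on a saturated chain carbon, two bonds along the chain from a double-bonded chain carbon. The 2,2,6-trimethylcyclohexyl that leaves carries two defined stereocentres, while the cyclohexyl that enters carries none. Among the compounds with values here, no measured step bears on this change; the only step available alters an oxygen on the aromatic ring and leaves the saturated chain untouched. Within the data shown here, the size of the step for compound 3 in this assay therefore rests on no direct precedent. Stripping the ring of its methyl groups is a larger alteration than the one measured, so for compound 3 a modest rise in the number is expected, a 2.0-fold higher number from compound 1 to compound 3 (0.31 log units; beyond the scatter), with wide uncertainty either way. Compound 3 is estimated at 4000 nM, within 1300 nM to 12000 nM.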

Compound 3, half-maximal inhibitory concentration: 8430 nM
Estimate against measurement, compound 3: 2.1-fold (0.32 log units) below, and the stated range covers the measured number.
By their numbers in this assay, from the lowest: compound 1; then compounds 2 and 3 (each within the scatter of the next).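

Cyclohexyl in place of 2,2,6-trimethylcyclohexyl on a saturated chain carbon, two bonds along the chain from a double-bonded chain carbon, gives a 4.3-fold higher number from compound 1 to compound 3 (0.63 log units; beyond the scatter) in this assay. This shows that the number responds to a change in this part of the molecule, which the earlier step on the aromatic oxygen left untouched, and compound 1 remains the lowest of the three. The change, however, shrinks the group from 9 heavy atoms to 6 and removes both defined stereocentres at once, so the step cannot be divided between the two. No evidence is available to explain the step.

The compounds shown leave open whether a cyclohexyl carrying only a single methyl group, a different stereoisomer of the 2,2,6-trimethylcyclohexyl, or a phenyl ring at this place would stay closer to compound 1. They also leave open how methyl on the aromatic oxygen would behave on the cyclohexyl compound, since the step from compound 1 to compound 2 is known only with the 2,2,6-trimethylcyclohexyl in place.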